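Furan-2-yl for cyclohexyl on the benzylic-type arm of compound 3

The source may hold more compounds than are shown below. What is called first, only, known or untested is meant among the compounds shown, and "the series" means these compounds.

Of the compounds shown here, three on the shared core have been measured in a functional assay on A549 cells (Homo sapiens) for antiproliferative activity, read by MTT assay, with a stated time of 72 h; a lower number here means a stronger inhibitor, a higher number a weaker inhibitor. Compound 1 `CCCSc1nc(Cl)c2c(n1)N(Cc1ccccc1)C(C(=O)N1CCN(C(=O)OC(C)(C)C)CC1)N2` gives 29000 nM. Compound 2 `CCCSc1nc(Cl)c2c(n1)N(Cc1ccccc1)C(C(=O)O)N2` gives 10700 nM. Compound 3 `CCCSc1nc(Cl)c2c(n1)N(CC1CCCCC1)C(C(=O)N1CCN(C)CC1)N2` gives 13200 nM. Among these three numbers compound 3 holds the second highest; its nearest neighbour is compound 2, whose value sits within the scatter of it, while the value of compound 1 lies furthest away and beyond the scatter. Within the data shown here, no single-change step connects any two of the measured compounds, so the three values only say that all of them are weak inhibitors of roughly the same order.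

Compound 4 `CCCSc1nc(Cl)c2c(n1)N(Cc1ccco1)C(C(=O)N1CCN(C)CC1)N2` is not yet measured. It differs from compound 3 in one place: furan-2-yl in place of cyclohexyl on a saturated chain carbon bound to a nitrogen on an aromatic ring in a ring, that is, cyclohexylmethyl becomes (furan-2-yl)methyl. Among the measured compounds shown here, nothing among the measured compounds reports what this exchange does in this assay. Given that compound 3 gives 13200 nM and that every measured value here falls in the same weak range, a step from compound 3 to compound 4 of a 1.1-fold higher number from compound 3 to compound 4 (0.06 log units; within the scatter) is expected, which is none beyond the scatter. Compound 4 is therefore estimated at 15000 nM, with a range from 5000 nM to 45000 nM.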

Compound 4, half-maximal inhibitory concentration: 13600 nM
For compound 4 the middle estimate is 1.1-fold (0.04 log units) above the measured one; measured number inside the range.
By their numbers in this assay, from the lowest: compounds 2, 3 and 4 (each within the scatter of the next); then compound 1.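

Among these compounds, compound 3 and compound 4 provide the first single-change comparison on the shared core in this assay, and replacing cyclohexyl with furan-2-yl on the saturated chain carbon bound to a nitrogen on an aromatic ring gives a 1.0-fold higher number from compound 3 to compound 4 (0.01 log units; within the scatter), so the two compounds cannot be told apart. At this place, then, a six-membered non-aromatic ring of carbon only and a five-membered aromatic ring with a hetero atom and a hydrogen-bond acceptor read alike, and this one exchange gives no sign that the assay separates the two arms. Nothing available explains why the two compounds read alike.

The compounds shown leave open whether an arm carrying an amine or a carboxylic acid, or a longer chain between the furan-2-yl ring and the nitrogen, would depart from this value. They also leave open whether furan-2-yl and cyclohexyl would still read alike with a different group at the carbonyl, such as the free carboxylic acid of compound 2.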